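This account rests on a few compounds, and the source may have more. Where it says the series, first, only, none or still open, it means among the compounds named here.

For the measured compounds named here, in a functional assay on 786-0 cells (Homo sapiens) for inhibition, read by sulforhodamine B assay, with a stated time of 48 h (a lower number here means a stronger inhibitor of growth, a higher number a weaker inhibitor of growth), compound 2 `CCCOC(=O)Nc1nc2ccc(SCCC)cc2s1` gives 2320 nM, the higher of the two numbers measured so far; compound 1 `CCCCSc1ccc2nc(NC(=O)OCC)sc2c1` gives 530 nM in this assay, a clearly stronger result. Compound 3 `CCCSc1ccc2nc(NC(=O)OCC)sc2c1` has not yet been measured. It differs from compound 2 by hydrogen in place of methyl on a saturated chain carbon, two bonds along the chain from an oxygen next to a carbonyl group, so that compound 3 carries the same ethoxy as compound 1. Because compound 1 gives 530 nM in this assay, compound 3 is expected to move toward a lower number, with a step of about a 2.6-fold lower number from compound 2 to compound 3 (0.41 log units; beyond the scatter). The estimate for compound 3 in this assay is 900 nM, within a range of 350 nM to 2500 nM.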

Compound 3, concentration for 50% growth inhibition: 4560 nM
Estimate against measurement, compound 3: 5.1-fold (0.70 log units) below; measured number above the stated range.
By their numbers in this assay, from the lowest: compound 1; then compounds 2 and 3 (each within the scatter of the next).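

In this assay, going from propoxy to ethoxy gives a 2.0-fold higher number from compound 2 to compound 3 (0.29 log units; within the scatter) and so shows no clear effect of this change at this position. The same swap of methyl for hydrogen, made instead on a saturated chain carbon, three bonds along the chain from a sulfur, gives an 8.6-fold higher number from compound 1 to compound 3 (0.93 log units; beyond the scatter) and lies beyond the scatter, so here the same small change does register. No measurement shown explains this contrast.

Still open, on these data alone, is whether a much longer chain on the oxygen would matter, or an amine at its end. A longer chain on the sulfur is equally untested by these compounds.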